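Swapping a Five-Membered Ring on a Shared Thiophene Core

The compounds below may be only part of what the source reports. "The series", "measured", "known", "first", "only" and "open" are said of these compounds alone.

Compound 1 `CC(C)(C)Cc1c(-c2ccoc2)sc(N)c1C(=O)c1ccc(Cl)cc1`: 1%
Compound 2 `Cc1noc(C)c1-c1sc(N)c(C(=O)c2ccc(Cl)cc2)c1CC(C)(C)C`: 1%

Of the compounds shown here, two built on the same core have been measured in an assay on CHO cells for displacement of a labelled ligand from adenosine receptor A1 (Homo sapiens), read by scintillation counting, tested at 10 uM; on this read-out higher numbers stand for more inhibition at the one concentration tested (going by the name of the read-out) and lower numbers for less inhibition. Compound 1 `CC(C)(C)Cc1c(-c2ccoc2)sc(N)c1C(=O)c1ccc(Cl)cc1` gives 1% in this assay, and compound 2 `Cc1noc(C)c1-c1sc(N)c(C(=O)c2ccc(Cl)cc2)c1CC(C)(C)C` gives 1%. For the measured compounds named here, the one step between them, no change at the digits printed from compound 1 to compound 2 (within the scatter), shows that exchanging one small aromatic ring for another at this position left the read-out where it was. Compound 2 therefore stands level with compound 1 at the digits shown; neither displaces the labelled ligand to any noticeable degree at the concentration tested.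

Compound 3 `CC(C)(C)Cc1c(-c2cn[nH]c2)sc(N)c1C(=O)c1ccc(Cl)cc1` is the next variation: 1H-pyrazol-4-yl in place of 3,5-dimethyl-1,2-oxazol-4-yl on an aromatic carbon. Going by the values given here, the group that enters carries one hydrogen-bond donor where the departing group had none, but the only step available, the one from compound 1 to compound 2, is within the scatter, and it concerns the same position. On that basis the expected step of a number 2 percentage points higher from compound 2 to compound 3 (within the scatter) is none beyond the scatter. For compound 3 the estimate in this assay is 3%, with a range from -8% to 15%.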

Compound 3, a percentage reported as inhibition, at one concentration (the size of the read-out at that concentration, not a potency): 1%
Estimate against measurement, compound 3: 2 percentage points above, and the stated range covers the measured number.
By their numbers in this assay, from the lowest: compounds 1, 2 and 3 (each within the scatter of the next).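

Two more steps now join the first in this assay: no change at the digits printed from compound 2 to compound 3 (within the scatter), and no change at the digits printed from compound 1 to compound 3 (within the scatter). For the compounds shown here, the single earlier step covered only one pair of rings, whereas three five-membered aromatic rings on the aromatic carbon next to the ring sulfur now sit level, even though 1H-pyrazol-4-yl and 3,5-dimethyl-1,2-oxazol-4-yl differ in heavy atoms and in their counts of hydrogen-bond donors and acceptors. No measurement at hand explains this flat result, and the values alone cannot tell whether this read-out is insensitive to the ring here or whether all three compounds simply fail to displace the labelled ligand for a reason lying elsewhere in the molecule.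

The compounds shown leave open whether anything other than a five-membered aromatic ring at this carbon would give a different reading, such as a phenyl ring, a carboxylic acid, an aminomethyl group or a longer alkyl chain. They also leave open what would happen if the neopentyl group or the (4-chlorophenyl)carbonyl group were replaced, since both stay the same throughout.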